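This account rests on a few compounds, and the source may have more. Where it says the series, first, only, none or still open, it means among the compounds named here.

Measured compounds:
compound 1, `O/N=C(\CCN1CCN(c2ccccn2)CC1)c1cccc(F)c1`: 17.1 nM
compound 2, `Cc1cccc(/C(CCN2CCN(c3ccccn3)CC2)=N/O)c1`: 2.3 nM

Compound 2 stands at the lowest of the two numbers in a functional assay on HEK293 cells with D(4) dopamine receptor (Homo sapiens) as the target, read by FLIPR; a lower number here means that less compound is needed, a higher number that more compound is needed for the effect; its nearest neighbour is compound 1, which gives 17.1 nM in this assay. Among the compounds with values here, the one measured step, a 7.4-fold lower number from compound 1 to compound 2 (0.87 log units; beyond the scatter), is a methyl in place of fluoro on an aromatic carbon, and it is the only change yet seen.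

Compound 3, `O/N=C(\CCN1CCN(c2ccccn2)CC1)c1ccc(F)cc1`, is not yet measured. Relative to compound 2 the change is 4-fluorophenyl in place of 3-methylphenyl on a carbon with a double bond to nitrogen. This undoes the methyl of compound 2 and reintroduces fluoro, though not at the same aromatic carbon, so the step from compound 1 to compound 2 bears on it only in part: that step was modest and beyond the scatter, and a return in the opposite direction is the most that can be read from it. Within the data shown here, no measured step speaks to moving the fluoro within the ring.

For compound 3 a higher number than compound 2 is therefore expected, roughly a 6.1-fold higher number from compound 2 to compound 3 (0.78 log units; beyond the scatter), landing near compound 1. The estimate for compound 3 in this assay is 14 nM, with a range from 4 nM to 55 nM.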

Compound 3, half-maximal effective concentration: 31 nM
Estimate against measurement, compound 3: 2.2-fold (0.35 log units) below; the measured number falls inside the stated range.
By their numbers in this assay, from the lowest: compound 2; then compounds 1 and 3 (each within the scatter of the next).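

In this assay, within the data shown here, the change to 4-fluorophenyl in place of 3-fluorophenyl gives a 1.8-fold higher number from compound 1 to compound 3 (0.26 log units; within the scatter) and so does not separate the two fluoro compounds, the first reading of where fluoro sits on this ring. The step of 4-fluorophenyl in place of 3-methylphenyl on the carbon with a double bond to nitrogen gives a 13-fold higher number from compound 2 to compound 3 (1.13 log units; beyond the scatter) and is large, so among these three compounds the 3-methylphenyl of compound 2 stands apart from both fluorophenyl groups rather than from just one of them. Nothing shown bears on the reason for this separation or for the lack of one between the fluoro compounds.

Still open, as far as these compounds go, is whether the low number of compound 2 goes with the methyl group itself or with its place on the ring, which a 4-methylphenyl group set against compound 2 would address. Also open, from the compounds shown here alone, is how an unsubstituted phenyl, a 3-chlorophenyl or a 3-methoxyphenyl group would read on the same carbon, and thus whether methyl is unusual or fluoro simply gives the higher numbers.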